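Substitution on the hydrazide nitrogen: notes toward compound 4

The compounds below may be only part of what the source reports. "The series", "measured", "known", "first", "only" and "open" are said of these compounds alone.

Compound 3 `CC(=O)NN(C(=O)NCc1ccccc1)c1ccccc1` is known in a functional assay on the whole organism with Mus musculus as the target, in the maximal electroshock model (a lower number here means that less compound is needed, a higher number that more compound is needed for the effect), only as a limit of the assay, > 30 mg/kg. The parent compound 1 `CC(=O)NNC(=O)NCc1ccccc1` gives 95 mg/kg in this assay. Compound 2 `CC(=O)NN(C)C(=O)NCc1ccccc1` likewise reaches only a limit, > 30 mg/kg. Compound 4 `CC(=O)NN(C(=O)NCc1ccccc1)c1nccs1` differs from compound 3 by 1,3-thiazol-2-yl in place of phenyl on an amide-type nitrogen. Within the data shown here, the steps that bear on this position, a step that the limit leaves unreadable from compound 1 to compound 3 and a step that the two limits leave unreadable from compound 2 to compound 3, together with a step that the limit leaves unreadable from compound 1 to compound 2, all rest on the limit of > 30 mg/kg in this assay, at which 2 of the 3 values shown sit, and yield no readable size. No direction can therefore be drawn from them for a further aromatic group on the amide-type nitrogen. The expected value for compound 4 in this assay is 60 mg/kg, within 25 mg/kg to 200 mg/kg, with a fair chance of another limit. The step this estimate implies, a step that the limit leaves unreadable from compound 3 to compound 4, is expected to stay within the scatter.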

Compound 4, dose for half-maximal effect: 6.2 mg/kg
Estimate against measurement, compound 4: 9.7-fold (0.99 log units) above; the whole stated range lies above it.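

In this assay a substituent on the amide-type nitrogen now gives readable steps, with 1,3-thiazol-2-yl in place of phenyl (an at least 4.8-fold lower number from compound 3 to compound 4 (0.68 log units; beyond the scatter)), in place of methyl (an at least 4.8-fold lower number from compound 2 to compound 4 (0.68 log units; beyond the scatter)) and in place of hydrogen (a 15-fold lower number from compound 1 to compound 4 (1.19 log units; beyond the scatter)). Among these compounds, the choice of aromatic ring at this position therefore matters, which the earlier steps, none of them readable, could not show: the limit of > 30 mg/kg in this assay, at which 2 of the 4 values shown sit.

On these data alone, whether the lower number goes with the ring nitrogen, the ring sulfur or the five-membered ring as such stays open. So does the outcome with pyridin-2-yl or 1,3-oxazol-2-yl on this nitrogen.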